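The compounds below may be only part of what the source reports. "The series", "measured", "known", "first", "only" and "open" are said of these compounds alone.

For the measured compounds named here, the series shares one core; compound 1 `CCCCc1nc(=O)c(S(=O)(=O)c2ccc(-c3ccnc(NC(=O)C4CC4)c3)cc2)c(O)n1-c1c(OC)cccc1OC` carries a 2-((cyclopropylcarbonyl)amino)pyridin-4-yl group and is the only member with a number. In an ADME assay on microsomes from liver (Rattus norvegicus) for metabolic stability, using NADPH, with a stated time of 10 min (on this read-out lower numbers stand for a less stable compound and higher numbers for a more stable compound), compound 1 gives 72%. Compound 2 `CCCCc1[nH]c(=O)c(S(=O)(=O)c2ccc(-c3ccc(F)cc3)cc2)c(O)c1-c1c(OC)cccc1OC` has in this assay only the entry "not determined" (no result reported), and compound 3 `CCCCc1[nH]c(=O)c(S(=O)(=O)c2ccc(-c3cccnc3OC)cc2)c(O)c1-c1c(OC)cccc1OC` has in this assay only the entry "not determined" (no result reported), so compound 1 stands alone on the numbers shown, with nothing to rank it against. Compound 4 `CCCCc1nc(=O)c(S(=O)(=O)c2ccccc2)c(O)n1-c1c(OC)cccc1OC` differs from compound 1 by hydrogen in place of 2-((cyclopropylcarbonyl)amino)pyridin-4-yl on an aromatic carbon. Going by the values given here, no measured pair shows what such a change does in this assay, and the three entries supply no step to lean on. In this assay the step is expected to be small, a number 4 percentage points lower from compound 1 to compound 4 (within the scatter), within the scatter and in no settled direction. For compound 4 the expected value in this assay is 68%, with a range of 45% to 90%.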

Compound 4, percent of the compound remaining: 93%
Estimate against measurement, compound 4: 25 percentage points below; measured number above the stated range.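

For the compounds shown here, replacing the 2-((cyclopropylcarbonyl)amino)pyridin-4-yl group with hydrogen on this aromatic carbon gives, in this assay, a number 21 percentage points higher from compound 1 to compound 4 (beyond the scatter), the first readable step for the series. The substituent at this position therefore matters for this read-out, and the large group is not needed for the higher value. No measurement shown bears on the reason for this step.

On these data alone, whether an amine or a carboxylic acid at this position would give a value nearer compound 1 or compound 4 remains open. Also open, as far as these compounds go, is whether the step follows from the whole group or only from its cyclopropyl part.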